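A Fluorinated Cyclopropyl Replaces the Propyl Chain

The source may hold more compounds than are shown below. What is called first, only, known or untested is meant among the compounds shown, and "the series" means these compounds.

Of the compounds shown here, three have been measured in an assay on SH-EP1 cells for displacement of a labelled ligand from Neuronal acetylcholine receptor; alpha4/beta2 (Homo sapiens), read by scintillation counting; a lower number here means a stronger inhibitor, a higher number a weaker inhibitor. Compound 2 `CCCC(=O)N1CC2CC(C1)N2` gives 14 nM and stands at the lowest of the three numbers. For the measured compounds named here, its nearest neighbour is compound 3 `O=C(CC1C=CCC1)N1CC2CC(C1)N2`, which gives 53 nM; the step of a 3.8-fold higher number from compound 2 to compound 3 (0.58 log units; beyond the scatter) is the only single-point change among the measured compounds. Compound 1 `O=C(C1CC1)N1CC2CC1CN2`, built on a different core, gives 2800 nM, and its two values next to compound 2 show a wide gap, but the two structures differ in more than one place, so the gap is not a single step.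

Compound 4 `O=C([C@@H]1C[C@@H]1F)N1CC2CC(C1)N2` is the next candidate. It differs from compound 2 in one place: 2-fluorocyclopropyl in place of propyl on a carbonyl carbon. Going by the values given here, the only measured step that bears on this change is the one from compound 2 to compound 3, where a ring-bearing group in place of a short chain on the same core gave a modest move toward weaker binding. The new group in compound 4 is of similar size to the propyl it replaces, so a step of no more than modest size is expected in this assay, if anything toward a higher number. On that basis compound 4 is estimated at 30 nM, within 8 nM to 120 nM, which corresponds to an expected step of a 2.1-fold higher number from compound 2 to compound 4 (0.33 log units; beyond the scatter).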

Compound 4, inhibition constant: 1.7 nM
Compound 4: middle estimate off by 18-fold (1.25 log units), on the high side; the measured number lies below the stated range.
By their numbers in this assay, from the lowest: compound 4; then compound 2; then compound 3; then compound 1.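

In this assay, 2-fluorocyclopropyl in place of propyl on the carbonyl carbon gives an 8.2-fold lower number from compound 2 to compound 4 (0.92 log units; beyond the scatter), showing that this position on the shared core can move toward a lower number as well as a higher one. The only earlier step at this position, a 3.8-fold higher number from compound 2 to compound 3 (0.58 log units; beyond the scatter), ran the other way, so among these compounds a ring in the group does not by itself set the direction of the change: the cyclopent-2-en-1-yl group of compound 3 and the 2-fluorocyclopropyl group of compound 4 lie on opposite sides of compound 2. No measurement shown here accounts for the shift.

As far as these compounds go, what remains open is how the step divides between the three-membered ring and the fluorine, a question that plain cyclopropyl on the shared core would address directly, with the cyclopropyl of compound 1 offering no answer on its different core. Also open, from the compounds shown here alone, is what the two defined stereocentres contribute, which the opposite stereoisomer of the 2-fluorocyclopropyl group would test, along with whether a 2,2-difluorocyclopropyl or 2-methylcyclopropyl group would follow compound 4.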